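A chloro for fluoro step from compound 2

The source may report more compounds than this note shows. Statements on the series, on what has been measured and on what is new or still open speak of the compounds shown alone.

Compound 1 (`CN1CCN(C2CCN(c3nccc4[nH]c(-c5ccc(F)c(F)c5)nc34)CC2)CC1`), compound 2 (`CN1CCN(CC2CCN(c3nccc4[nH]c(-c5ccc(F)c(F)c5)nc34)CC2)CC1`) and compound 3 (`CN1CCN(C(=O)C2CCN(c3nccc4[nH]c(-c5ccc(F)c(F)c5)nc34)CC2)CC1`) share one core and differ in the group on a saturated ring carbon. In a physicochemical assay for solubility, read by HPLC, using the shake flask method, in phosphate buffer, with a stated time of 20 h, at pH 6.5 (on this read-out higher numbers stand for higher solubility and lower numbers for lower solubility), compound 1 gives 130000 nM, compound 2 gives 195000 nM and compound 3 gives 200000 nM. Compound 2 therefore stands within the scatter of both other compounds, as a 1.5-fold higher number from compound 1 to compound 2 (0.18 log units; within the scatter) and a 1.0-fold higher number from compound 2 to compound 3 (0.01 log units; within the scatter) show. The remaining step, a 1.5-fold higher number from compound 1 to compound 3 (0.19 log units; within the scatter), is also within the scatter.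

Compound 4 (`CN1CCN(CC2CCN(c3nccc4[nH]c(-c5ccc(F)c(Cl)c5)nc34)CC2)CC1`) departs from compound 2 by one change, (chloro in place of fluoro on an aromatic carbon). This places chloro in place of fluoro on an aromatic carbon, ortho to a fluoro group and meta to a large group, giving 3-chloro-4-fluorophenyl from 3,4-difluorophenyl. Going by the values given here, no measured step touches this aromatic carbon, so those three steps bear on it only indirectly, and none of them leaves the scatter. No step beyond the scatter is therefore expected in this assay, with a slightly lower number as the likelier direction. The estimated step is a 1.3-fold lower number from compound 2 to compound 4 (0.11 log units; within the scatter). Compound 4 is estimated at 150000 nM, with an expected range from 70000 nM to 280000 nM.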

Compound 4, solubility: 155000 nM
For compound 4 the middle estimate is 1.0-fold (0.01 log units) below the measured one; the measured number falls inside the stated range.
By their numbers in this assay, from the lowest: compounds 1, 4, 2 and 3 (each within the scatter of the next).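

In this assay, the step of a 1.3-fold lower number from compound 2 to compound 4 (0.10 log units; within the scatter) stays within the scatter, so compound 4 cannot be told apart from compound 2 on this read-out. Going by these compounds alone, the earlier compounds differed only in the group on a saturated ring carbon, whereas this is the first reading at the aromatic carbon ortho to a fluoro group and meta to a large group. Here too, going from 3,4-difluorophenyl to 3-chloro-4-fluorophenyl leaves the step inside the scatter, and nothing available offers an account of this result.

The compounds shown leave open whether a nitrile, a methoxy group or a carboxylic acid on this aromatic carbon would also stay within the scatter. They also leave open whether chloro in place of fluoro would read the same alongside the groups of compound 1 and compound 3.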